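The source may report more compounds than this note shows. Statements on the series, on what has been measured and on what is new or still open speak of the compounds shown alone.

In a functional assay on MOLT-4 cells (Homo sapiens) for inhibition (a higher number here means a weaker inhibitor, a lower number a stronger inhibitor), compound 1 `COc1cccc(/C=C2\Cc3ccccc3C2=O)c1` is reported only as a limit, > 500000 nM. Among the measured compounds shown here, compound 2 `O=C1CCCCC/C1=C\c1cccc(Cl)c1` gives 88600 nM, the only actual number so far. Compound 3 `O=C1CCCCC/C1=C\c1cccc([N+](=O)[O-])c1` differs from compound 2 at one place: nitro in place of chloro on an aromatic carbon. For the measured compounds named here, no measured pair shows what this exchange does, and no step beyond the scatter is expected in this assay, in either direction. The expected change is small, a 1.1-fold lower number from compound 2 to compound 3 (0.04 log units; within the scatter). For compound 3 the estimated value is 80000 nM, with an expected range of 25000 nM to 300000 nM.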

Compound 3, half-maximal inhibitory concentration: 39200 nM
Compound 3: the middle estimate sits 2.0-fold (0.31 log units) above what was measured, and the stated range covers the measured number.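

Among the compounds shown here, at this aromatic carbon the substituent matters in this assay: nitro in place of chloro gives a 2.3-fold lower number from compound 2 to compound 3 (0.35 log units; beyond the scatter), the first step between two actual numbers. The position is therefore not indifferent to what it carries, though the step is modest. No measurement shown gives a reason for this step. As far as these compounds go, whether an amine or a carboxylic acid on this carbon would lower the number further stays open. So does whether the same exchange would act alike on the core of compound 1, whose reported value is only a limit.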